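The source may report more compounds than this note shows. Statements on the series, on what has been measured and on what is new or still open speak of the compounds shown alone.

Measured in an ADME assay on HEK293 cells (Homo sapiens) for cytotoxicity, with a stated time of 72 h (a higher number here means that more compound is needed for the effect, a lower number that less compound is needed), each value a limit:
- compound 1 `CCOc1ccc(/C=C/[C@@](C)(/C=C/c2ccc(O)cc2)CCC=C(C)C)cc1`: > 36600 nM
- compound 2 `CC(C)=CCC[C@@](C)(/C=C/c1ccc(C)cc1)/C=C/c1ccc(O)cc1`: > 36600 nM
- compound 3 `CC(C)=CCC[C@](C)(/C=C/c1ccc(O)cc1)/C=C/c1cccc(F)c1`: > 36600 nM

Compound 3 has no number of its own, since compound 3 reads > 36600 nM, which is a limit. It shares this position with the other two compounds, so all three measured compounds stand at the limit of > 36600 nM in this assay, at which 3 of the 3 values shown sit.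

Compound 4 `CC(C)=CCC[C@](C)(/C=C/c1ccc(O)cc1)/C=C/c1cccc(Cl)c1` differs from compound 3 in one place, (chloro in place of fluoro on an aromatic carbon). This puts chloro in place of fluoro on an aromatic carbon, meta to a large group.

Within the data shown here, no measured pair makes this exchange. The closest changes replace the whole substituted phenyl group: 3-fluorophenyl in place of 4-ethoxyphenyl gives a step that the two limits leave unreadable from compound 1 to compound 3, and 3-fluorophenyl in place of 4-methylphenyl gives a step that the two limits leave unreadable from compound 2 to compound 3. The remaining change, methyl in place of ethoxy, gives a step that the two limits leave unreadable from compound 1 to compound 2. None of these has a size that can be carried over, so no step beyond the scatter is expected in this assay, in either direction.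

With every measured compound at the limit of > 36600 nM in this assay, at which 3 of the 3 values shown sit, compound 4 is expected to be reported as a limit too. The estimate for compound 4 is 40000 nM, with an expected range from 20000 nM to 80000 nM. This estimate means a step that the limit leaves unreadable from compound 3 to compound 4.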

Compound 4, half-maximal effective concentration: > 36600 nM
Compound 4: no number, only a limit; the forecaster's own chance of this, stated with the estimate: 85%; the middle value lies beyond the limit too.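

In this assay compound 4 gives > 36600 nM, which is a limit, so its steps from compound 1, compound 2 and compound 3 cannot be read. All four compounds stand at the same position: the limit of > 36600 nM in this assay, at which 4 of the 4 values shown sit. The compounds shown leave open how far apart they truly lie, and whether chloro in place of fluoro changes the read-out at all.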